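Replacing the methyl on the ring nitrogen: an estimate

A few compounds are considered here, and "the series" means these few. Any claim that something is new, unique, unknown or untested is made for them only; others in the source may bear on it.

Measured compounds:
compound 1 `CCCCCNc1cccc2c(S(=O)(=O)Nc3onc(C)c3C)cccc12` gives 80 nM in an assay on VSM-A10 cells for antagonist activity at Endothelin-1 receptor (Rattus norvegicus); on this read-out lower numbers stand for stronger inhibition and higher numbers for weaker inhibition;
compound 2 `Cc1noc(NS(=O)(=O)c2cccc3c(NC(=O)C(C)C)cccc23)c1C` gives 880 nM in this assay;
compound 3 `CNc1cccc2c(S(=O)(=O)Nc3onc(C)c3C)cccc12` gives 130 nM in this assay.

Two steps place compound 3: one is a 1.6-fold higher number from compound 1 to compound 3 (0.21 log units; within the scatter), within the scatter, and the other is a 6.8-fold lower number from compound 2 to compound 3 (0.83 log units; beyond the scatter), beyond it. Compound 4 `Cc1noc(NS(=O)(=O)c2cccc3c(N/C(S)=N/c4ccccc4)cccc23)c1C` differs from compound 3 in one place: a group of 9 heavy atoms (7 carbon, 1 nitrogen, 1 sulfur; one six-membered aromatic ring of carbon only) in place of one carbon atom, on a nitrogen on an aromatic ring. The steps that touch this nitrogen are an 11-fold higher number from compound 1 to compound 2 (1.04 log units; beyond the scatter) and a 6.8-fold lower number from compound 2 to compound 3 (0.83 log units; beyond the scatter); both show that the isopropylcarbonyl on it goes with a far higher number than a plain alkyl, while a 1.6-fold higher number from compound 1 to compound 3 (0.21 log units; within the scatter) shows chain length hardly matters. The entering group resembles the acyl of compound 2 more than the methyl of compound 3. Compound 4 is therefore expected to show a step in this assay of a 4.6-fold higher number from compound 3 to compound 4 (0.66 log units; beyond the scatter). Compound 4 is estimated at 600 nM, between 200 nM and 2500 nM.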

Compound 4, half-maximal inhibitory concentration: 150 nM
For compound 4 the middle estimate is 4.0-fold (0.60 log units) above the measured one; measured number below the stated range.
By their numbers in this assay, from the lowest: compounds 1, 3 and 4 (each within the scatter of the next); then compound 2.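

In this assay, the group of 9 heavy atoms with its six-membered aromatic ring sits on this nitrogen with no shift beyond the scatter, a 1.2-fold higher number from compound 3 to compound 4 (0.06 log units; within the scatter) and a 1.9-fold higher number from compound 1 to compound 4 (0.27 log units; within the scatter). The same group set against the isopropylcarbonyl gives a 5.9-fold lower number from compound 2 to compound 4 (0.77 log units; beyond the scatter), so among these four compounds the number of heavy atoms on this nitrogen does not track the read-out, and compound 2 alone stands apart. Nothing available here explains this result. The compounds shown leave open whether a benzoyl or a plain acetyl on this nitrogen would stay with compound 2 or join compounds 1, 3 and 4.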